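Urea aryl swap on a shared core: compound 3 expected

The compounds below may be only part of what the source reports. "The series", "measured", "known", "first", "only" and "open" are said of these compounds alone.

For the measured compounds named here, compound 2 `Cc1ccc(NC(=O)Nc2cccc(CNc3nccnc3Cl)c2)cc1` stands highest of the two numbers so far in a functional assay on MGC-803 cells (Homo sapiens) for antiproliferative activity, read by MTT assay, with a stated time of 48 h (a lower number here means a stronger inhibitor, a higher number a weaker inhibitor), where compound 2 gives 11900 nM. Its nearest neighbour is compound 1 `Cc1ccc(NC(=O)Nc2cccc(CNc3nccnc3Cl)c2)cc1C`, which in this assay gives 9870 nM; the step of a 1.2-fold higher number from compound 1 to compound 2 (0.08 log units; within the scatter) lies within the scatter, so the two compounds cannot be ordered.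

Compound 3 `O=C(Nc1cccc(CNc2nccnc2Cl)c1)Nc1ccccc1Cl` differs from compound 2 in one place: 2-chlorophenyl in place of 4-methylphenyl on an amide-type nitrogen. Going by the values given here, the only measured step, from compound 1 to compound 2, also alters the same aryl group on the urea, and it was small: a 1.2-fold higher number from compound 1 to compound 2 (0.08 log units; within the scatter). Among the compounds with values here, that step is the single piece of evidence bearing on the new change, and because it is a 1.2-fold higher number from compound 1 to compound 2 (0.08 log units; within the scatter), no shift beyond the scatter is expected from the present swap either. Within the data shown here, the move to a chlorine-bearing ring has no precedent among the measured compounds, so the range is kept wide.

Compound 3 is therefore expected to give about 10000 nM in this assay, within a range of 4000 nM to 30000 nM, a step of a 1.2-fold lower number from compound 2 to compound 3 (0.08 log units; within the scatter) that is expected to stay within the scatter.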

Compound 3, half-maximal inhibitory concentration: 7130 nM
For compound 3 the middle estimate is 1.4-fold (0.15 log units) above the measured one, and the stated range covers the measured number.
By their numbers in this assay, from the lowest: compounds 3, 1 and 2 (each within the scatter of the next).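

In this assay, 2-chlorophenyl in place of 4-methylphenyl on an amide-type nitrogen gives a 1.7-fold lower number from compound 2 to compound 3 (0.22 log units; within the scatter), and 2-chlorophenyl in place of 3,4-dimethylphenyl at the same place gives a 1.4-fold lower number from compound 1 to compound 3 (0.14 log units; within the scatter). The earlier pair showed only that losing one methyl from this aryl group leaves the number within the scatter; these steps extend that to a swap of methyl-bearing rings for a chlorine-bearing one, so that all three aryl groups shown here cannot be ordered at this place. No measured property or other data accompany these compounds that could account for the result, and what the steps reflect cannot be said from them.

As far as these compounds go, it remains open whether any aryl group at this place can move the number beyond the scatter, for instance a ring carrying a nitrile, an amine or a carboxylic acid, or a longer chain in place of the ring. From the compounds shown here alone, all three compounds also share the same core outside this aryl group, so the effect of changes elsewhere in that core remains unknown.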